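The source may report more compounds than this note shows. Statements on the series, on what has been measured and on what is new or still open speak of the compounds shown alone.

Compound 1, `O=C(CSC(=S)N[C@H]1CCOC1=O)Nc1ccc(Cl)cc1`, gives > 128000 nM in a functional assay on SMMC-7721 cells (Homo sapiens) for cytotoxicity, read by MTT assay, with a stated time of 72 h (a higher number here means a weaker inhibitor, a lower number a stronger inhibitor), a limit of the assay and not a number.
Compound 2, `O=C(CSC(=S)N[C@H]1CCOC1=O)Nc1ccccc1`, gives > 128000 nM in this assay, again only a limit.
Compound 3, `O=C(CSC(=S)N[C@H]1CCOC1=O)Nc1ccc(C(=O)/C=C/c2ccc(Cl)cc2)cc1`, gives > 128000 nM in this assay, also only a limit.

From compound 1 to compound 2 the change is hydrogen in place of chloro on an aromatic carbon. The size of the step that the two limits leave unreadable from compound 1 to compound 2 is not readable because of the limit of > 128000 nM in this assay, at which 3 of the 3 values shown sit. Compound 3 carries a core unlike that of compound 1; the difference between the two cores is not broken down here. Compound 4, `O=C(CSC(=S)N[C@H]1CCOC1=O)Nc1ccc(C(=O)/C=C/c2ccccc2)cc1`, has not yet been measured in this assay. It differs from compound 3 by hydrogen in place of chloro on an aromatic carbon, the same change as that from compound 1 to compound 2, set in the same place. Because (the limit of > 128000 nM in this assay, at which 3 of the 3 values shown sit), that earlier pair gives no size to carry over, and the three measured compounds give no number at all. Compound 4 is therefore expected to sit at the same limit, with an estimated 150000 nM between 100000 nM and 300000 nM. The expected step is a step that the limit leaves unreadable from compound 3 to compound 4, meaning no readable change. This rests on compound 3 standing at > 128000 nM, itself a limit.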

Compound 4, half-maximal inhibitory concentration: > 128000 nM
Compound 4: no number, only a limit; the forecaster's own chance of this, stated with the estimate: 85%; the middle value does not contradict the limit.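

The steps from compound 1, compound 2 and compound 3 to compound 4 cannot be read, since compound 4 also gives only a limit of the assay and not a number: the limit of > 128000 nM in this assay, at which 4 of the 4 values shown sit.

The compounds shown leave open whether swapping chloro for hydrogen, or adding the (2-phenylethenyl)carbonyl group, changes the read-out in this assay at all.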